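The source may report more compounds than this note shows. Statements on the series, on what has been measured and on what is new or still open speak of the compounds shown alone.

Measured so far in an ADME assay on microsomes from liver (Mus musculus) for metabolic stability, with a stated time of 10 min; a lower number here means that less of the compound is left, a higher number that more of the compound is left:
compound 1 `C[C@]1(C(=O)O)CC[C@H](C(=O)N2CC[C@](c3ccc(C(F)(C(F)(F)F)C(F)(F)F)cc3)(S(=O)(=O)c3ccc(F)cc3)C2)CC1`: 93%
compound 2 `C[C@]1(C(=O)N2CC[C@](c3ccc(C(F)(C(F)(F)F)C(F)(F)F)cc3)(S(=O)(=O)c3ccc(F)cc3)C2)CC[C@H](C(=O)O)CC1`: 95%

The step from compound 1 to compound 2 swaps the acid and amide positions on the ring; in this assay the change was a number 2 percentage points higher from compound 1 to compound 2 (within the scatter). Compound 2 stands highest of the two numbers, with compound 1 nearest and within the scatter.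

Compound 3 `C[C@]1(C(=O)N2CC[C@](c3ccc(C(F)(C(F)(F)F)C(F)(F)F)cc3)(S(=O)(=O)c3ccc(F)cc3)C2)CC[C@@H](C(=O)O)CC1` differs from compound 2 only by configuration: the two compounds have the same atoms and bonds and differ only in configuration as drawn: 2 of 3 stereo elements differ; a stereocentre at a saturated ring carbon is drawn r in compound 2 and s in compound 3; a stereocentre at a saturated ring carbon is drawn R in compound 2 and S in compound 3. Going by the values given here, no measured step involves an inversion of this kind, so the only guide is that both compounds so far sit high and close together. A step of a number 3 percentage points lower from compound 2 to compound 3 (within the scatter) is therefore expected, none beyond the scatter. For compound 3 the estimate in this assay is 92%, with a range of 82% to 99%.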

Compound 3, percent of the compound remaining: 100%
Estimate against measurement, compound 3: 8 percentage points below; the whole stated range lies below it.
By their numbers in this assay, from the lowest: compounds 1, 2 and 3 (each within the scatter of the next).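

In this assay, going by these compounds alone, inverting the drawn configuration of the 4-carboxy-1-methylcyclohexyl group leaves the read-out within the scatter, with a number 5 percentage points higher from compound 2 to compound 3 (within the scatter), and stereochemistry is the only variable in this pair: the fact that compounds 2 and 3 differ only in the configuration as drawn. The comparison with the 4-carboxy-4-methylcyclohexyl group gives a number 7 percentage points higher from compound 1 to compound 3 (within the scatter), so the three compounds cannot be ranked in this assay. Neither arrangement of the methyl and acid nor the configuration tested separates them here.

Going by these compounds, it remains open whether a primary amide or hydroxymethyl group in place of the carboxylic acid would hold the read-out at this level. The same applies to hydrogen in place of the methyl.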